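A few compounds are considered here, and "the series" means these few. Any claim that something is new, unique, unknown or untested is made for them only; others in the source may bear on it.

Working notes on the series in a physicochemical assay for lipophilicity, read by NMR; a lower number here means a more polar compound, a higher number a more lipophilic compound.

Within the data shown here, compound 1, `CC(F)(F)COc1ccc2[nH]ccc2c1`, gives 2.7 in this assay and stands highest of the three numbers measured so far. The two small fluorinated alcohols sit well below it: compound 3, `CC(O)CC(C)(F)F`, gives 0.66, the nearer of the two, and compound 2, `OCCC(F)C(F)F`, gives 0.29, the furthest; both gaps to compound 1 lie beyond the scatter. Among the measured compounds shown here, no two of the measured compounds differ in only one place, so no single structural step has been read directly yet.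

Compound 4, `FC(F)(F)CCOc1ccc2[nH]ccc2c1`, has not been measured. It differs from compound 1 by 2,2,2-trifluoroethyl in place of 1,1-difluoroethyl on a saturated chain carbon bound to an oxygen on an aromatic ring: a fluorinated two-carbon chain stays on the oxygen bound to the aromatic ring, with one fewer carbon and one more fluorine. Without a measured step of this kind in the series, the expectation is a small movement, if any, from compound 1 to compound 4, estimated as a number 0.10 log units lower from compound 1 to compound 4 (within the scatter) in this assay, a step not beyond the scatter. Compound 4 is therefore expected to give about 2.6, within a range of 2.2 to 3.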

Compound 4, partition coefficient: 2.8
Estimate against measurement, compound 4: 0.20 log units below, within the range that was stated.
By their numbers in this assay, from the lowest: compound 2; then compound 3; then compounds 1 and 4 (each within the scatter of the next).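

Among these compounds, a reading of a number 0.10 log units higher from compound 1 to compound 4 (within the scatter) in this assay is the first single-place step the series offers, and it falls on a saturated chain carbon bound to an oxygen on an aromatic ring. At this position, 2,2,2-trifluoroethyl in place of 1,1-difluoroethyl, 5 heavy atoms in place of 4, therefore gives two compounds that this read-out does not separate, a result the two small fluorinated alcohols could not supply. No measurement available here bears on the origin of this step.

As far as these compounds go, what an unfluorinated ethyl group or a longer fluorinated chain would give at this place remains open. So does whether the same exchange would read alike on a core other than that of compound 1.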